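Shifting the hydroxyl on the last aryl ring of the core

The source may report more compounds than this note shows. Statements on the series, on what has been measured and on what is new or still open speak of the compounds shown alone.

Measured so far:
compound 1, `Oc1ccccc1-c1cc(-c2ccccc2C(F)(F)F)cc(-c2ccccc2O)n1`, 4770 nM
compound 2, `Oc1cccc(-c2cc(-c3ccccc3C(F)(F)F)cc(-c3ccccc3O)n2)c1`, 7250 nM
compound 3, `Oc1cccc(-c2cc(-c3ccc(OC(F)(F)F)cc3)cc(-c3ccccc3O)n2)c1`, 21100 nM

In a functional assay on DU-145 cells (Homo sapiens) for inhibition (on this read-out lower numbers stand for stronger inhibition and higher numbers for weaker inhibition), compound 1 gives 4770 nM, while compound 2 gives 7250 nM. Going by the values given here, the one change between them, (3-hydroxyphenyl in place of 2-hydroxyphenyl on an aromatic carbon), moved the number by a 1.5-fold higher number from compound 1 to compound 2 (0.18 log units; within the scatter). Compound 3 gives the highest number of the three, 21100 nM; the difference between its core and that of compound 1 is not broken down here. Compound 4, `Oc1cccc(-c2cc(-c3ccc(OC(F)(F)F)cc3)cc(-c3cccc(O)c3)n2)c1`, is not yet measured and differs from compound 3 by 3-hydroxyphenyl in place of 2-hydroxyphenyl on an aromatic carbon. This is the same kind of change as from compound 1 to compound 2, but the surroundings differ: there it sat meta to a 2-(trifluoromethyl)phenyl group and a 2-hydroxyphenyl group, here meta to a 3-hydroxyphenyl group and a large group. Since the earlier step was a 1.5-fold higher number from compound 1 to compound 2 (0.18 log units; within the scatter), a similarly small step is expected, a 1.3-fold higher number from compound 3 to compound 4 (0.12 log units; within the scatter). Compound 4 is therefore estimated at 28000 nM in this assay, expected between 12000 nM and 65000 nM.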

Compound 4, half-maximal inhibitory concentration: > 50000 nM
Compound 4 ended at the assay's limit; the forecaster's own chance of this, stated with the estimate: 25%; middle value at least 1.7-fold (0.25 log units) away from the limit.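

In this assay compound 4 gives > 50000 nM, which is a limit of the assay and not a number. On these data alone, on this core, putting 3-hydroxyphenyl in place of 2-hydroxyphenyl gives an at least 2.3-fold higher number from compound 3 to compound 4 (0.37 log units; beyond the scatter), a step that can be read even though its true size stays unknown. The data therefore do not show whether the change has the same size on both cores or a different one: the same change on two cores in this assay, a 1.5-fold higher number (0.18 log units; within the scatter) from compound 1 to compound 2 and an at least 2.3-fold higher number (0.37 log units; beyond the scatter) from compound 3 to compound 4; the limit leaves it open whether they differ.

As far as these compounds go, the true value of compound 4 remains open, and a more sensitive reading would be needed to compare the two steps. All the compounds shown carry hydroxyl groups on these aryl rings, so it is also open how a methoxy group or an amine in their place would read.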